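The compounds below may be only part of what the source reports. "The series", "measured", "known", "first", "only" and "open" are said of these compounds alone.

Compound 2 `COc1ccc(/C=N/Nc2ncc3c(n2)n(C2CCCC2)c(=O)c(=O)n3C)cc1` gives 26300 nM in a functional assay on PC-3 cells (Homo sapiens) for antiproliferative activity, read by MTT assay (on this read-out lower numbers stand for stronger inhibition and higher numbers for weaker inhibition), the lowest of the two numbers recorded; compound 1 `Cc1cccc(/C=N/Nc2ncc3c(n2)n(C2CCCC2)c(=O)c(=O)n3C)c1` gives 53600 nM in this assay. Within the data shown here, the only measured step, a 2.0-fold lower number from compound 1 to compound 2 (0.31 log units; beyond the scatter), exchanges both the substituent and its place on the ring and so bears on the present change only loosely. Compound 3 `Cn1c(=O)c(=O)n(C2CCCC2)c2nc(N/N=C/c3ccccc3F)ncc21` differs from compound 2 by 2-fluorophenyl in place of 4-methoxyphenyl on a carbon with a double bond to nitrogen. Among the measured compounds shown here, with a single step of modest size as the sole guide, and no measured compound carrying a fluorine or a substituent at that position, no direction can be read off with confidence; the removal of the methoxy group that accompanied the lower number of compound 2 suggests, if anything, a slight drift back toward a higher number. Compound 3 is therefore expected to show a 1.5-fold higher number from compound 2 to compound 3 (0.18 log units; within the scatter) in this assay, with an estimated value of 40000 nM and a range from 13000 nM to 120000 nM.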

Compound 3, half-maximal inhibitory concentration: 27600 nM
Beside the measured number, compound 3's estimate is 1.4-fold (0.16 log units) above it; the range from low to high includes it.
By their numbers in this assay, from the lowest: compounds 2, 3 and 1 (each within the scatter of the next, the first and the last beyond it).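

In this assay, replacing 4-methoxyphenyl with 2-fluorophenyl gives a 1.0-fold higher number from compound 2 to compound 3 (0.02 log units; within the scatter), so at this carbon the methoxy group is not needed to hold the level seen so far. Replacing 3-methylphenyl with 2-fluorophenyl gives a 1.9-fold lower number from compound 1 to compound 3 (0.29 log units; within the scatter), so the 2-fluorophenyl compound cannot be told apart from either earlier compound, even though those two differ from each other by more than the scatter. No measurement is available to explain these numbers.

The three ring substituents differ in both identity and place, so the compounds shown do not separate what the substituent contributes from what its place on the ring contributes. From the compounds shown here alone, it also remains open whether an amine or a carboxylic acid on the ring, or a longer chain in place of the ring, would move the number outside this narrow band.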